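Pyridin-4-yl in place of phenyl: working notes

The compounds below may be only part of what the source reports. "The series", "measured", "known", "first", "only" and "open" are said of these compounds alone.

Values in an ADME assay on SH-SY5Y cells (Homo sapiens) for cytotoxicity, read by MTT assay, with a stated time of 24 h; on this read-out lower numbers stand for stronger inhibition and higher numbers for weaker inhibition:
Compound 1 `Nc1ncccc1/N=C/c1ccnc(NC(=O)C2CC2)c1`: > 200000 nM, a limit of the assay
Compound 2 `Nc1ncc(-c2ccccc2)cc1/N=C/c1ccnc(NC(=O)C2CC2)c1`: 158000 nM
Compound 3 `Nc1ncc(-c2ccncc2)cc1/N=C/c1ccnc(NC(=O)C2CC2)c1`: not yet measured

For the measured compounds named here, at 158000 nM, compound 2 holds the only actual number. Compound 3 differs from compound 2 as follows: pyridin-4-yl in place of phenyl on an aromatic carbon. Going by the values given here, one measured step bears on this change, the entry of phenyl in place of hydrogen at the same aromatic carbon: an at least 1.2-fold lower number from compound 1 to compound 2 (0.10 log units; that floor lies within the scatter). Among the compounds with values here, no measured step replaces phenyl itself, so no step beyond the scatter is expected in this assay. The estimated step is a 1.1-fold higher number from compound 2 to compound 3 (0.06 log units; within the scatter). For compound 3 the expected value is 180000 nM, with an estimated range of 90000 nM to 280000 nM.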

Compound 3, half-maximal inhibitory concentration: > 200000 nM
Compound 3 ended at the assay's limit; the forecaster's own chance of this, stated with the estimate: 45%; middle value at least 1.1-fold (0.04 log units) away from the limit.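

Pyridin-4-yl in place of phenyl gives an at least 1.2-fold higher number from compound 2 to compound 3 (0.10 log units; that floor lies within the scatter) in this assay at this aromatic carbon. That step is a floor and not a size: compound 3 gives a limit of the assay. The step from compound 1 to compound 3 cannot be read: the limit of > 200000 nM in this assay, at which 2 of the 3 values shown sit.

Open, on these data alone, is whether an amine, a carboxylic acid or a longer chain on this aromatic carbon would give a number lower than compound 2 by more than the scatter in this assay at all. As far as these compounds go, how far compound 3 lies past its limit also stays open.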